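A few compounds are considered here, and "the series" means these few. Any claim that something is new, unique, unknown or untested is made for them only; others in the source may bear on it.

Measured compounds:
compound 1, `O=C(NC1CCCCC1)C1CCN(Cc2ccc(Cl)cc2)CC1`: 7.7 nM
compound 2, `O=C(C1CCN(Cc2ccccc2)CC1)N1CCc2ccccc2C1`: 8.8 nM

Both were tested in an assay for displacement of a labelled ligand from Sigma non-opioid intracellular receptor 1 (Cavia porcellus); a lower number here means a stronger inhibitor, a higher number a weaker inhibitor. Compound 1 gives the lower of the two numbers, but its gap to compound 2 lies within the usual scatter, so the two cannot be told apart on these data.

Compound 3, `CC(C)NC(=O)C1CCN(Cc2ccc(Cl)cc2)CC1`, has not yet been measured. Its change from compound 1 is isopropyl in place of cyclohexyl on an amide-type nitrogen. Among the measured compounds shown here, no measured pair shows this kind of change, so the expected step rests only on the size of the change itself. A modest loss is expected: the step from compound 1 to compound 3 is estimated at a 3.2-fold higher number from compound 1 to compound 3 (0.51 log units; beyond the scatter). Compound 3 is therefore expected to give about 25 nM, with a likely range from 8 nM to 80 nM.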

Compound 3, inhibition constant: 637 nM
For compound 3 the middle estimate is 25-fold (1.41 log units) below the measured one; measured number above the stated range.
By their numbers in this assay, from the lowest: compounds 1 and 2 (each within the scatter of the next); then compound 3.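

In this assay, the group on this amide-type nitrogen matters greatly: isopropyl in place of cyclohexyl gives an 83-fold higher number from compound 1 to compound 3 (1.92 log units; beyond the scatter), a large step. The earlier compounds shown here differ from each other in more than one place, so they could not show this sensitivity. Nothing measured here accounts for the size of this step.

On these data alone, whether the ring itself or the number of carbons counts remains open. A hexyl chain on the same nitrogen, with six carbons but no ring, would help separate these two possibilities.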